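This account rests on a few compounds, and the source may have more. Where it says the series, first, only, none or still open, it means among the compounds named here.

Series notes. Compound 1 `CCCCc1cnc(CCCc2ccc(-c3ccccc3C(=O)O)cc2)[nH]1`, compound 2 `O=C(O)c1ccccc1-c1ccc(CCc2ncc(CC3CCC3)[nH]2)cc1` and compound 3 `CCCCc1cnc(C(Cc2ccc(-c3ccccc3C(=O)O)cc2)C(C)C)[nH]1` share the same core and differ in the group carried on it and in the chain linking the two ring parts. In an in vitro functional assay on cells for agonist activity at Bombesin receptor subtype-3 (Mus musculus), read by luminescence and calcium flux (a lower number here means that less compound is needed, a higher number that more compound is needed for the effect), compound 2 gives 7.1 nM, the lowest of the three numbers; compound 1 gives 382 nM and compound 3 gives 2240 nM, both gaps to compound 2 lying beyond the scatter. Compound 4 `O=C(O)c1ccccc1-c1ccc(CCc2ncc(Cc3ccccc3Cl)[nH]2)cc1` carries 2-chlorophenyl in place of cyclobutyl on a saturated chain carbon bound to an aromatic carbon. Among the compounds with values here, no measured pair isolates this change, so the expectation rests on compound 2 alone. The expected step is a 2.1-fold higher number from compound 2 to compound 4 (0.32 log units; beyond the scatter), a modest move toward a higher number that may still sit within the scatter. Compound 4 is expected at 15 nM, between 3 nM and 80 nM.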

Compound 4, half-maximal effective concentration: 22 nM
The estimate for compound 4 lay 1.5-fold (0.17 log units) below the measured number; low and high end bracket the measured number.
By their numbers in this assay, from the lowest: compound 2; then compound 4; then compound 1; then compound 3.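

Replacing cyclobutyl with 2-chlorophenyl on a saturated chain carbon bound to an aromatic carbon gives a 3.1-fold higher number from compound 2 to compound 4 (0.49 log units; beyond the scatter) in this assay. Within the data shown here, this is the first single-place comparison. It shows that this position accepts a larger, aromatic, chlorine-bearing group (7 heavy atoms against 4) at the cost of only a modest step.

The compounds shown do not separate the contribution of the ring from that of the chlorine, which a plain phenyl or a 2-methoxyphenyl at this place would address. No measurement at hand explains the step.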